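This account rests on a few compounds, and the source may have more. Where it says the series, first, only, none or still open, it means among the compounds named here.

In an assay on L1.2 cells for binding affinity to C-C chemokine receptor type 8 (Homo sapiens) (a higher number here means a weaker inhibitor, a lower number a stronger inhibitor), compound 3, `CCOC(=O)N1CCC(NS(=O)(=O)c2ccc(NC(=O)c3ccccc3)c3ccccc23)CC1`, gives 0.17 nM, the lowest of the three numbers. Compound 2, `O=C(Nc1ccc(S(=O)(=O)NC2CCCCC2)c2ccccc12)c1ccccc1`, gives 4.4 nM, and compound 1, `O=C(Nc1ccc(S(=O)(=O)N2CCOCC2)c2ccccc12)c1ccccc1`, gives 7750 nM. Both measured steps, a 1800-fold lower number from compound 1 to compound 2 (3.25 log units; beyond the scatter) and a 26-fold lower number from compound 2 to compound 3 (1.41 log units; beyond the scatter), altered the group on the sulfonamide nitrogen. Compound 4, `CCOC(=O)N1CCC(NS(=O)(=O)c2ccc(OC(=O)c3ccccc3)c3ccccc23)CC1`, instead differs from compound 3 at the other end of the shared core: benzoyloxy in place of benzamido on an aromatic carbon. Going by the values given here, no measured step touches this part of the structure, so the earlier steps give no direct guide to the size or direction of this one. A moderate weakening is nonetheless expected for compound 4, an 8.8-fold higher number from compound 3 to compound 4 (0.95 log units; beyond the scatter), with a wide range to reflect the lack of precedent. Compound 4 is estimated at 1.5 nM, between 0.2 nM and 15 nM.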

Compound 4, inhibition constant: 16.4 nM
Beside the measured number, compound 4's estimate is 11-fold (1.04 log units) below it; measured number above the stated range.
By their numbers in this assay, from the lowest: compound 3; then compound 2; then compound 4; then compound 1.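

Benzoyloxy in place of benzamido brings a 96-fold higher number from compound 3 to compound 4 (1.98 log units; beyond the scatter) in this assay and shows that this end of the shared core counts too, not only the group on the sulfonamide nitrogen. The two groups hold the same number of heavy atoms and differ in one atom, nitrogen with its hydrogen-bond donor against oxygen, so that single exchange is enough for a large step. Nothing measured here says why the step is this large. Still open, as far as these compounds go, is whether a urea, a reversed amide or a simple amine at this place would keep the low number of compound 3.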